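Hexyl in place of propyl on the selenocyanate carbamate

A few compounds are considered here, and "the series" means these few. Any claim that something is new, unique, unknown or untested is made for them only; others in the source may bear on it.

Three members of this selenocyanate carbamate series carry numbers in a functional assay on MCF7 cells (Homo sapiens) for cytotoxicity, read by MTT assay, with a stated time of 72 h; a lower number here means a stronger inhibitor of growth, a higher number a weaker inhibitor of growth. Compound 1 `COc1ccc(OC(=O)Nc2ccc([Se]C#N)cc2)cc1` gives 22400 nM in this assay. Compound 2 `CC(C)COC(=O)Nc1ccc([Se][Se]c2ccc(NC(=O)OCC(C)C)cc2)cc1`, the diselenide dimer with two isobutyl carbamates, gives 19000 nM in this assay. Compound 3 `CCCOC(=O)Nc1ccc([Se]C#N)cc1` gives 8000 nM in this assay, which is the lowest of the three numbers; its gaps to compound 2 and to compound 1 both lie beyond the usual scatter, so compound 3 is the strongest inhibitor of growth among the measured set.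

The next compound, compound 4 `CCCCCCOC(=O)Nc1ccc([Se]C#N)cc1`, differs from compound 3 in one place: propyl in place of hydrogen on a saturated chain carbon, three bonds along the chain from an oxygen next to a carbonyl group. The shared core and the selenocyanate are untouched; only the carbamate ester chain grows from propyl to hexyl.

Within the data shown here, no measured pair within the set reports this kind of chain extension, so the size of the step is open. The change adds only saturated carbon and nothing that is counted as a donor or acceptor, and the expectation is a small step, at most marginally beyond the scatter, leaning toward a lower number; the expected step is a 1.3-fold lower number from compound 3 to compound 4 (0.12 log units; within the scatter). For compound 4 the estimate in this assay is 6000 nM, with a range from 2000 nM to 18000 nM.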

Compound 4, concentration for 50% growth inhibition: 6600 nM
Estimate against measurement, compound 4: 1.1-fold (0.04 log units) below, and the stated range covers the measured number.
By their numbers in this assay, from the lowest: compounds 4 and 3 (each within the scatter of the next); then compounds 2 and 1 (each within the scatter of the next).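

In this assay, propyl in place of hydrogen on a saturated chain carbon, three bonds along the chain from an oxygen next to a carbonyl group, gives a 1.2-fold lower number from compound 3 to compound 4 (0.08 log units; within the scatter). Among these compounds, this is the first one-place comparison: with the shared core and the selenocyanate held fixed, the move from propyl to hexyl on the carbamate ester leaves the two compounds indistinguishable in this read-out, so this position accepts the added propyl without a resolved step in either direction. No measurement available for this series offers an account of that result.

Going by these compounds, a single step cannot show how the number behaves along the chain, so it remains open whether a longer chain such as octyl or decyl stays level with hexyl, and whether an amine or a carboxylic acid at the chain end would do the same. On these data alone, it is also open whether a hexyl carbamate behaves the same way when the selenocyanate is exchanged for the diselenide dimer.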